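A Sulfamoyl Swap on a Weakly Antiproliferative Core

This account rests on a few compounds, and the source may have more. Where it says the series, first, only, none or still open, it means among the compounds named here.

All three measured compounds share one core and differ only in the aryl group on an aromatic nitrogen. Compound 1 `N#CC1=C(N)Oc2c(c3nc4ccccc4nc3c3ccccc23)C12C(=O)N(Cc1cnnn1-c1cccc(Cl)c1)c1ccccc12` bears a 3-chlorophenyl there, and in an ADME assay on L02 cells (Homo sapiens) for antiproliferative activity, read by MTT assay, with a stated time of 48 h (a higher number here means a weaker inhibitor, a lower number a stronger inhibitor), compound 1 gives 35200 nM. Compound 2 `N#CC1=C(N)Oc2c(c3nc4ccccc4nc3c3ccccc23)C12C(=O)N(Cc1cnnn1-c1ccccc1Br)c1ccccc12` carries a 2-bromophenyl instead. For compound 2 the reported > 50000 nM is a limit of the assay, not a number. Compound 3 `N#CC1=C(N)Oc2c(c3nc4ccccc4nc3c3ccccc23)C12C(=O)N(Cc1cnnn1-c1ccc(N)cc1)c1ccccc12` carries a 4-aminophenyl. For compound 3 as well, the reading of > 50000 nM is a limit rather than a number. Compound 3 therefore stands at the weak end of this small set, as the limit of > 50000 nM in this assay, at which 2 of the 3 values shown sit, records. The steps read an at least 1.4-fold higher number from compound 1 to compound 2 (0.15 log units; that floor lies within the scatter) and an at least 1.4-fold higher number from compound 1 to compound 3 (0.15 log units; that floor lies within the scatter), while a step that the two limits leave unreadable from compound 2 to compound 3.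

Compound 4 `N#CC1=C(N)Oc2c(c3nc4ccccc4nc3c3ccccc23)C12C(=O)N(Cc1cnnn1-c1ccc(S(N)(=O)=O)cc1)c1ccccc12` differs from compound 3 by sulfamoyl in place of amino on an aromatic carbon. Going by the values given here, no measured step alters this position in the same way, and both steps from compound 1 only reach a floor within the scatter. The expected step is thus a step that the limit leaves unreadable from compound 3 to compound 4, no change beyond the scatter. Compound 4 is estimated at 60000 nM, between 30000 nM and 150000 nM, most likely reported again only as a limit.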

Compound 4, half-maximal inhibitory concentration: > 50000 nM
Compound 4: a limit, no number; the forecaster's own chance of this, stated with the estimate: 80%; the middle value does not contradict the limit.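

Compound 4 also gives a limit rather than a number, the same reading as compound 2 and compound 3: the limit of > 50000 nM in this assay, at which 3 of the 4 values shown sit. So at this position on the aromatic ring, two different groups, the small amino and the larger sulfamoyl, both leave the compound at that limit in this assay. Compared with the 3-chlorophenyl compound, the new group gives an at least 1.4-fold higher number from compound 1 to compound 4 (0.15 log units; that floor lies within the scatter), while the steps to compound 4 from compound 2 and from compound 3 cannot be read, as both ends of each are limits.

On these data alone, how compound 3 and compound 4 truly compare therefore stays open, and the swap of amino for sulfamoyl has no readable size. As far as these compounds go, it is also open whether another group in this place, such as a carboxylic acid or a methoxy group, would give a number instead of a limit.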